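Acetyl in place of methylsulfonyl on an amine nitrogen

A few compounds are considered here, and "the series" means these few. Any claim that something is new, unique, unknown or untested is made for them only; others in the source may bear on it.

In a functional assay on HCT-116 cells (Homo sapiens) for antiproliferative activity, read by sulforhodamine B assay, with a stated time of 72 h (a higher number here means a weaker inhibitor, a lower number a stronger inhibitor), compound 1 `CNC(=O)C[C@@H]1C[C@@H](c2ccc(Cl)c(Cl)c2)[C@H](NC(=O)c2cc(-c3c(Cl)cnn3C)c(Cl)o2)CN1` gives 450 nM, compound 3 `Cn1ncc(Cl)c1-c1cc(C(=O)N[C@@H]2CN[C@H](CCCO)C[C@H]2c2ccc(Cl)c(Cl)c2)oc1Cl` gives 510 nM and compound 2 `Cn1ncc(Cl)c1-c1cc(C(=O)N[C@@H]2CN[C@H](CCNS(C)(=O)=O)C[C@H]2c2ccc(F)c(F)c2)oc1Cl` gives 920 nM. Compound 2 thus lies within the scatter of compound 3 and just beyond the scatter of compound 1. Compound 4 `CC(=O)NCC[C@@H]1C[C@@H](c2ccc(F)c(F)c2)[C@H](NC(=O)c2cc(-c3c(Cl)cnn3C)c(Cl)o2)CN1` carries acetyl in place of methylsulfonyl on an amine nitrogen, turning 2-(methanesulfonamido)ethyl into 2-acetamidoethyl: acetyl in place of methylsulfonyl on an amine nitrogen. For the measured compounds named here, no measured step makes this exchange. The only one available, a 1.1-fold higher number from compound 1 to compound 3 (0.05 log units; within the scatter), puts 2-hydroxyethyl in place of methylcarbamoyl and bears on it only loosely. Little is therefore expected to move in this assay, with no step beyond the scatter and no favoured direction. The expected step is a 1.1-fold lower number from compound 2 to compound 4 (0.03 log units; within the scatter). For compound 4 the estimate is 850 nM, with an expected range of 420 nM to 1700 nM.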

Compound 4, half-maximal inhibitory concentration: 920 nM
The estimate for compound 4 lay 1.1-fold (0.03 log units) below the measured number, and the stated range covers the measured number.
By their numbers in this assay, from the lowest: compounds 1, 3, 2 and 4 (each within the scatter of the next, the first and the last beyond it).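

In this assay, for the compounds shown here, the first direct exchange on this amine nitrogen, acetyl in place of methylsulfonyl, gives no change at the digits printed from compound 2 to compound 4 (within the scatter) and so shows that, with the rest of compound 2 unchanged, the two groups cannot be told apart here. The number therefore does not depend on which of these two groups sits on the nitrogen of this chain. No evidence is available to explain this result.

Still open, from the compounds shown here alone, is whether a free amine or a carboxylic acid at the end of this chain would shift the number. Going by these compounds, a longer chain carrying the acetamido group also remains untested in these data.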